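This account rests on a few compounds, and the source may have more. Where it says the series, first, only, none or still open, it means among the compounds named here.

Working notes on the series. Compound 1 `O=C(Nc1ccc(-n2ncc3c(Cl)cccc32)cc1)Nc1ccc(Cl)c(C(F)(F)F)c1` is the reference point. Among the measured compounds shown here, in a functional assay on MDA-MB-231 cells (Homo sapiens) for cytotoxicity, read by MTT assay, with a stated time of 72 h (a higher number here means a weaker inhibitor, a lower number a stronger inhibitor), compound 1 gives 1600 nM, the lowest of the three numbers so far. Compound 2 `O=C(Nc1ccc(-n2ncc3c(Br)cccc32)cc1)Nc1ccc(Cl)c(C(F)(F)F)c1` gives 7700 nM in this assay, and compound 3 `O=C(Nc1ccc(-n2ncc3cnccc32)cc1)Nc1ccc(Cl)c(C(F)(F)F)c1` gives 16000 nM. The measured steps are a 4.8-fold higher number from compound 1 to compound 2 (0.68 log units; beyond the scatter), a 10-fold higher number from compound 1 to compound 3 (1.00 log units; beyond the scatter) and a 2.1-fold higher number from compound 2 to compound 3 (0.32 log units; beyond the scatter). Both changes made at the 4-chloro-1H-indazol-1-yl group of compound 1 raise the number, the exchange of one halogen for another the less, the exchange of the whole bicycle for one carrying a ring nitrogen and no halogen the more.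

Compound 4 `O=C(Nc1ccc(-n2ncc3cccnc32)cc1)Nc1ccc(Cl)c(C(F)(F)F)c1` is not yet measured. Its change from compound 1 is a group of 9 heavy atoms (6 carbon, 3 nitrogen; one five-membered aromatic ring with 2 hetero atoms, one six-membered aromatic ring with 1 hetero atom) in place of a group of 10 heavy atoms (7 carbon, 2 nitrogen, 1 chlorine; one five-membered aromatic ring with 2 hetero atoms, one six-membered aromatic ring of carbon only), on an aromatic carbon. For the measured compounds named here, the step from compound 1 to compound 3 is the one that bears on it: that step also removes the chlorine and brings a ring nitrogen into the six-membered ring, though compound 3 and compound 4 are distinct isomers of that ring, and no measured pair separates the loss of the halogen from the gain of the nitrogen. A step toward a higher number, of roughly the size seen for compound 3, is therefore expected in this assay. For compound 4 the estimate is 10000 nM, range 4000 nM to 25000 nM, which is an expected step of a 6.3-fold higher number from compound 1 to compound 4 (0.80 log units; beyond the scatter).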

Compound 4, half-maximal inhibitory concentration: > 32000 nM
Compound 4 was reported as a limit (the forecaster's own chance of this, stated with the estimate: 10%); middle value at least 3.2-fold (0.50 log units) away from the limit.
By their numbers in this assay, from the lowest: compound 1; then compound 2; then compound 3. At a limit, above all of these: compound 4.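

In this assay compound 4 gives no number, only a limit: the limit of > 32000 nM in this assay, at which 1 of the 4 values shown sits.

Exchanging the 4-chloro-1H-indazol-1-yl group for the bicycle with a ring nitrogen and no halogen now gives a large step, an at least 20-fold higher number from compound 1 to compound 4 (1.30 log units; beyond the scatter), and the same exchange measured against the bromo analogue gives an at least 4.1-fold higher number from compound 2 to compound 4 (0.61 log units; beyond the scatter), so in both comparisons the nitrogen-containing bicycle of compound 4 lies on the higher side. For the two nitrogen-containing isomers, the step is an at least 2.0-fold higher number from compound 3 to compound 4 (0.30 log units; that floor lies within the scatter), and with that floor inside the scatter, these values do not establish that the position of the ring nitrogen matters.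

No pair shown separates the loss of the halogen from the gain of the ring nitrogen, and the true value of compound 4 beyond its limit remains unknown. Also open, as far as these compounds go, is whether a fluoro, methyl or methoxy group in place of the chlorine, on the bicycle without a ring nitrogen, would keep the number close to that of compound 1, or whether a chlorine kept on a bicycle with a ring nitrogen would do so.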